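Aryl group replacement on the shared core

A few compounds are considered here, and "the series" means these few. Any claim that something is new, unique, unknown or untested is made for them only; others in the source may bear on it.

Measured so far in an assay for displacement of a labelled ligand from Adrenergic receptor alpha-1 (Homo sapiens); on this read-out higher numbers stand for weaker inhibition and lower numbers for stronger inhibition:
compound 1 `CCOc1ccccc1N1CCN(CCCCn2ncc(=O)n(C)c2=O)CC1` gives 1.8 nM
compound 2 `Cn1c(=O)cnn(CCCCN2CCN(c3ccccn3)CC2)c1=O` gives 262 nM
compound 3 `Cn1c(=O)cnn(CCCCN2CCN(c3ccccc3S)CC2)c1=O` is reported only as a limit, > 10000 nM

Compound 1 holds the lowest of the two numbers in this assay; the nearest is compound 2, reached by the step of a 150-fold higher number from compound 1 to compound 2 (2.16 log units; beyond the scatter). Compound 3 stands at the assay limit of > 10000 nM in this assay, at which 1 of the 3 values shown sits, and gives no number; its step from compound 1, an at least 5500-fold higher number from compound 1 to compound 3 (3.74 log units; beyond the scatter), is therefore a minimum, as is the step from compound 2, an at least 38-fold higher number from compound 2 to compound 3 (1.58 log units; beyond the scatter).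

Compound 4 `Cn1c(=O)cnn(CCCCN2CCN(c3cccc(F)n3)CC2)c1=O` has not yet been measured. It differs from compound 1 as follows: 6-fluoropyridin-2-yl in place of 2-ethoxyphenyl on an amine nitrogen in a ring. Within the data shown here, the only measured step that bears on this change is the one from compound 1 to compound 2, in which pyridin-2-yl took the place of 2-ethoxyphenyl and the number rose by a large margin, well beyond the scatter. Compound 4 carries the same ring type, now as 6-fluoropyridin-2-yl, so a step of similar size and in the same direction is expected, a 140-fold higher number from compound 1 to compound 4 (2.14 log units; beyond the scatter). Compound 4 is accordingly estimated at 250 nM in this assay, within a range of 60 nM to 1200 nM; whether the fluorine shifts the number relative to compound 2 cannot be told from the data shown.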

Compound 4, inhibition constant: > 10000 nM
Compound 4 gave a limit, no number; the forecaster's own chance of this, stated with the estimate: 5%; middle value at least 40-fold (1.60 log units) away from the limit.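

Compound 4 is reported only as a limit and gives no number, so the series now holds two compounds at the same limit: the limit of > 10000 nM in this assay, at which 2 of the 4 values shown sit.

Among these compounds, on the pyridin-2-yl group, the single change of fluoro in place of hydrogen on an aromatic carbon gives an at least 38-fold higher number from compound 2 to compound 4 (1.58 log units; beyond the scatter), a minimum, so this carbon is not a neutral place for substitution in this assay. Measured against the 2-ethoxyphenyl group, the change to 6-fluoropyridin-2-yl gives an at least 5500-fold higher number from compound 1 to compound 4 (3.74 log units; beyond the scatter), also a minimum, which shows that the result for pyridin-2-yl cannot be carried over to a substituted pyridin-2-yl group.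

The step between compound 3 and compound 4 cannot be read, as both are limits, and neither compound can be placed relative to the other. On these data alone, it remains open whether the loss belongs to fluoro alone or would also follow from a methyl, a methoxy or a chloro group on the same aromatic carbon, and whether any such group would bring the number back towards that of compound 2.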